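Aryl ether swap on a shared core: estimate for compound 4

The compounds below may be only part of what the source reports. "The series", "measured", "known", "first", "only" and "open" are said of these compounds alone.

Compound 1 `Cc1nn(C)c(Oc2cccc(F)c2)c1/C=N\CCCCCOc1cc2oc(=O)cc(C)c2cc1Cl` gives 9870 nM in a functional assay on U-87MG ATCC cells for antiproliferative activity against U-87 MG (Homo sapiens), read by MTT assay, with a stated time of 72 h; on this read-out lower numbers stand for stronger inhibition and higher numbers for weaker inhibition.
Compound 2 `Cc1ccc(Oc2c(/C=N\CCCCCOc3cc4oc(=O)cc(C)c4cc3Cl)c(C)nn2C)cc1` gives 7970 nM in this assay.
Compound 3 `Cc1nn(C)c(Oc2ccc(F)cc2F)c1/C=N\CCCCCCOc1cc2oc(=O)cc(C)c2cc1Cl` gives > 25000 nM in this assay, which is a limit of the assay rather than a number.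

Compound 3 thus stands at the limit of > 25000 nM in this assay, at which 1 of the 3 values shown sits. Compound 4 `Cc1nn(C)c(Oc2ccc(I)cc2)c1/C=N\CCCCCCOc1cc2oc(=O)cc(C)c2cc1Cl` differs from it by 4-iodophenyl in place of 2,4-difluorophenyl on an oxygen on an aromatic ring. Among the measured compounds shown here, the only measured step at this same oxygen is a 1.2-fold lower number from compound 1 to compound 2 (0.09 log units; within the scatter), and that swap of one aryl group for another left the number essentially unchanged. Compound 3 also carries the six-carbon chain, for which no single-point comparison exists among the measured compounds. Compound 4 is therefore expected to remain weak, at an estimated 25000 nM with a range from 9000 nM to 60000 nM. This expectation corresponds to a step of a number no higher from compound 3 to compound 4 (the limit leaves the size open) that is estimated to stay within the scatter.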

Compound 4, half-maximal inhibitory concentration: 16800 nM
Compound 4: middle estimate off by 1.5-fold (0.17 log units), on the high side; measured number inside the range.
By their numbers in this assay, from the lowest: compounds 2, 1 and 4 (each within the scatter of the next, the first and the last beyond it). At a limit, above all of these: compound 3.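

With the chain of compound 3 kept, 4-iodophenyl in place of 2,4-difluorophenyl on this oxygen gives an at least 1.4-fold lower number from compound 3 to compound 4 (0.17 log units; that floor lies within the scatter). Among the compounds shown here, this is the first compound on that chain to read as a number rather than a limit in this assay. Compound 3 gives only a limit, so the true size of this step cannot be read: the limit of > 25000 nM in this assay, at which 1 of the 4 values shown sits.

From the compounds shown here alone, whether an amine or a carboxylic acid on this aryl ring, or a longer chain, would shift the number stays open. No pair shown differs in the chain alone, so its contribution also stays open.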